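Microsomal half-life notes: chloro on the fused core

A few compounds are considered here, and "the series" means these few. Any claim that something is new, unique, unknown or untested is made for them only; others in the source may bear on it.

Compound 1 `COc1cc(C2CCN(C[C@@H](C)O)CC2)ccc1Nc1ncc2ccc(-c3ccccc3N(C)S(C)(=O)=O)n2n1` reports a limit rather than a number in an in vitro ADME assay on microsomes from liver (Mus musculus, strain CD1) for metabolic stability, using NADPH, with a stated time of 10 min, tested at 0.5 uM (a higher number here means that the compound lasts longer, a lower number that the compound disappears faster), > 0.666 h.
Compound 2 `COc1cc(C2CCN(CC(N)=O)CC2)ccc1Nc1ncc2ccc(-c3ccccc3OC)n2n1` likewise reports a limit in this assay, > 0.666 h.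
Compound 3 `COc1cc(C2CCN(CC(N)=O)CC2)ccc1Nc1ncc2ccc(-c3ccccc3N(C)S(C)(=O)=O)n2n1` gives 0.483 h in this assay.

For the measured compounds named here, compound 3 thus stands as the only true number in the set; the other two values sit at the limit of > 0.666 h in this assay, at which 2 of the 3 values shown sit. The steps of an at least 1.3-fold lower number from compound 1 to compound 3 (0.13 log units; that floor lies within the scatter) and an at least 1.3-fold lower number from compound 2 to compound 3 (0.13 log units; that floor lies within the scatter) are each a floor within the scatter, and neither concerns the change now at hand.

Compound 4 `COc1cc(C2CCN(CC(N)=O)CC2)ccc1Nc1ncc2c(Cl)cc(-c3ccccc3N(C)S(C)(=O)=O)n2n1` differs from compound 3 by chloro in place of hydrogen on an aromatic carbon. Going by the values given here, no measured step addresses this change, so in this assay no step beyond the scatter is expected: a 1.0-fold lower number from compound 3 to compound 4 (0.00 log units; within the scatter). Compound 4 is therefore estimated at 0.48 h, with a range from 0.24 h to 0.95 h.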

Compound 4, half-life: > 0.666 h
Compound 4: a limit, no number (the forecaster's own chance of this, stated with the estimate: 25%); at least 1.3-fold (0.14 log units) between middle value and limit.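

Chloro in place of hydrogen on this aromatic carbon of the five-membered ring, two ring bonds from the ring nitrogen, gives an at least 1.3-fold higher number from compound 3 to compound 4 (0.13 log units; that floor lies within the scatter) in this assay. For the compounds shown here, this is the first reading at this position, and it shows no shorter half-life with chloro, though compound 4 reports only a limit. The true size of the step stays unread because the read-out stops at a limit: the limit of > 0.666 h in this assay, at which 3 of the 4 values shown sit.

On these data alone, whether a nitrile or a methyl group on this carbon would read the same remains open. So does the effect of chloro alongside the 1-hydroxyethyl group of compound 1.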